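Benzyloxy extension of compound 2 in this series

This account rests on a few compounds, and the source may have more. Where it says the series, first, only, none or still open, it means among the compounds named here.

Measured compounds:
compound 1 `Oc1ccccc1CNc1ccccc1` — "not active" (no number reported)
compound 2 `Oc1ccccc1CNc1ccc(-c2ccccc2)cc1` — 1820 nM
compound 3 `COc1ccc(-c2ccc(NCc3ccccc3O)cc2)cc1` — 580 nM

In a functional assay on Jurkat cells (Homo sapiens) for activation, with a stated time of 24 h (a lower number here means that less compound is needed, a higher number that more compound is needed for the effect), compound 1 gives "not active" (no number reported), compound 2 gives 1820 nM and compound 3 gives 580 nM. Compound 2 holds the highest of the two reported numbers; its nearest neighbour is compound 3, reached by a 3.1-fold lower number from compound 2 to compound 3 (0.50 log units; beyond the scatter). Compound 4 `Oc1ccccc1CNc1ccc(-c2cccc(OCc3ccccc3)c2)cc1` differs from compound 2 by benzyloxy in place of hydrogen on an aromatic carbon. Among the measured compounds shown here, the one step that bears on this is the methoxy addition on the same ring, a 3.1-fold lower number from compound 2 to compound 3 (0.50 log units; beyond the scatter), a modest lowering. For the measured compounds named here, no measured step covers benzyloxy itself or the place meta to a large group. The step from compound 2 to compound 4 is therefore expected to be modest and downward, a 2.0-fold lower number from compound 2 to compound 4 (0.31 log units; beyond the scatter), with wide uncertainty. Compound 4 is estimated at 900 nM (300 nM to 3000 nM).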

Compound 4, half-maximal effective concentration: "not active" (no number reported)
For compound 4 the study gives words and no number; there is nothing to compare the estimate with.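

In this assay, among the compounds shown here, compound 4 gives "not active" (no number reported) and no step from compound 2 to compound 4 can be read. Nothing measured here bears on this result. The compounds shown leave open whether any group other than benzyloxy, meta to a large group, would give a number.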